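Removing One Chloro From the Amide-Side Ring

The source may report more compounds than this note shows. Statements on the series, on what has been measured and on what is new or still open speak of the compounds shown alone.

Within the data shown here, compound 2 `Nc1ccccc1NC(=O)CCCNCC(=O)Nc1cc(Cl)ccc1Cl` has the lower of the two numbers measured so far. In a functional assay on the whole organism (Ehrlich cells, Mus musculus) for antiproliferative activity, with a stated time of 24 h, at a dose of 0.2 mmol/kg by the intraperitoneal route (on this read-out higher numbers stand for more inhibition at the one dose given (going by the name of the read-out) and lower numbers for less inhibition), compound 2 gives 50%, while compound 1 `Nc1ccccc1NC(=O)CCCNCC(=O)Nc1ccc(Br)cc1` gives 73.8%. Among the measured compounds shown here, the one step measured, a number 23.8 percentage points lower from compound 1 to compound 2 (beyond the scatter), replaced 4-bromophenyl with 2,5-dichlorophenyl on an amide-type nitrogen. Compound 3 `Nc1ccccc1NC(=O)CCCNCC(=O)Nc1ccccc1Cl` differs from compound 2 by hydrogen in place of chloro on an aromatic carbon, so the ring goes from 2,5-dichlorophenyl to 2-chlorophenyl. For the measured compounds named here, no measured step removes a single chloro from this ring, so the step from compound 1 to compound 2 bears on it only loosely: it shows that the substitution pattern on this ring can move the read-out by a modest amount. Compound 3 is therefore expected to lie between the two measured values, as a step of a number 10 percentage points higher from compound 2 to compound 3 (within the scatter). The estimate for compound 3 in this assay is 60%, with a range from 40% to 78%.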

Compound 3, a percentage reported as inhibition, in the whole organism at one dose (the size of the read-out at that dose, not a potency): 21.4%
Estimate against measurement, compound 3: 38.6 percentage points above, outside the stated range (below it).
By their numbers in this assay, from the lowest: compound 3; then compound 2; then compound 1.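

In this assay, the chloro para to a chloro group counts on its own: replacing it with hydrogen gives a number 28.6 percentage points lower from compound 2 to compound 3 (beyond the scatter), so the second chloro on this ring goes with more inhibition at the one dose given, not less. Among these compounds, this is the first change of a single atom on the ring, and it shows that the 2-chlorophenyl ring alone does not hold the read-out near the level of the 2,5-dichlorophenyl ring. Against the 4-bromophenyl ring, the change to 2-chlorophenyl gives a number 52.4 percentage points lower from compound 1 to compound 3 (beyond the scatter), a large step. Nothing measured here offers a reason for these steps.

Going by these compounds, it stays open whether fluoro or methoxy in place of this chloro would keep the read-out of compound 2 or fall to that of compound 3. Also open, on these data alone, is how a ring carrying bromo and chloro together would compare with compound 1.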